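Sulfonyl substituent on the pendant ring: methyl to phenyl

The compounds below may be only part of what the source reports. "The series", "measured", "known", "first", "only" and "open" are said of these compounds alone.

Measured in a functional assay on CHO.K1 cells for antagonist activity at prostaglandin D2 receptor 2 (Homo sapiens), read by GTPgammaS binding, with a stated time of 1 h; on this read-out higher numbers stand for weaker inhibition and lower numbers for stronger inhibition:
- compound 1 `COC(=O)c1ccc(Cc2c3c(n(CC(=O)O)c2C)CCNC3=O)c(S(=O)(=O)c2ccccc2)c1` gives 11 nM
- compound 2 `Cc1c(Cc2ccccc2S(=O)(=O)c2ccccc2F)c2c(n1CC(=O)O)CCNC2=O` gives 3.6 nM
- compound 3 `Cc1c(Cc2ccc(S(C)(=O)=O)cc2)c2c(n1CC(=O)O)CCNC2=O` gives 900 nM

Compound 3 stands highest of the three numbers in this assay, that is, it is the weakest inhibitor shown. Its nearest neighbour is compound 1 and its furthest is compound 2; both gaps lie beyond the scatter of repeated measurements, so the ranking of compound 3 at the bottom holds.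

Compound 4 `Cc1c(Cc2ccc(S(=O)(=O)c3ccccc3)cc2)c2c(n1CC(=O)O)CCNC2=O` has not yet been measured. It differs from compound 3 in one place: phenyl in place of methyl on a sulfonyl sulfur. Compound 4 thus carries the phenylsulfonyl group that compound 1 and compound 2 also carry, although on differently substituted rings and without their further groups.

A step toward stronger inhibition, well beyond the scatter, is expected from compound 3 to compound 4, because compound 1 with its phenylsulfonyl group gives 11 nM and compound 2 gives 3.6 nM. The expected step is a 30-fold lower number from compound 3 to compound 4 (1.48 log units; beyond the scatter). Compound 4 is estimated at 30 nM, within a range of 6 nM to 150 nM.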

Compound 4, half-maximal inhibitory concentration: 170 nM
For compound 4 the middle estimate is 5.7-fold (0.75 log units) below the measured one; measured number above the stated range.
By their numbers in this assay, from the lowest: compound 2; then compound 1; then compound 4; then compound 3.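

In this assay, phenyl in place of methyl on a sulfonyl sulfur gives a 5.3-fold lower number from compound 3 to compound 4 (0.72 log units; beyond the scatter). Within the data shown here, this is the only step so far that isolates this position, and it shows that the sulfonyl substituent bears on inhibition, with phenyl the better of the two groups tested there. Compound 1 and compound 2 also carry phenylsulfonyl but differ from compound 4 in more than one place, so their steps to it cannot be read, and no measurement on hand accounts for the gain at the sulfonyl sulfur.

From the compounds shown here alone, it remains open whether another substituent on the sulfur, such as benzyl, cyclohexyl or an amine, would give a lower number than phenyl. Also open, going by these compounds, is how a fluorine on the phenyl ring of compound 4 would alter its value.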